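Adding a group to the amine of compound 3

The compounds below may be only part of what the source reports. "The series", "measured", "known", "first", "only" and "open" are said of these compounds alone.

Among the compounds with values here, in a functional assay on HepG2 cells (Homo sapiens) for inhibition, read by MTT assay, with a stated time of 48 h (a lower number here means a stronger inhibitor, a higher number a weaker inhibitor), compound 3 (`CCOC(=O)C1=C(N)Nc2[nH]nc(C)c2C1c1ccc(N(C)C)cc1`) gives 4240 nM as the lowest of the three numbers so far. Compound 1 (`CCOC(=O)C1=C(N/C=N/c2nnc(S(N)(=O)=O)s2)Nc2[nH]nc(C)c2C1c1ccc(N(C)C)cc1`) gives 38100 nM in the same test, and compound 2 (`CCOC(=O)C(=NNC1=C(C(=O)OCC)C(c2ccc(N(C)C)cc2)c2c(C)n[nH]c2N1)C(=O)OCC`) gives 80800 nM there. Compound 4 (`CCOC(=O)C1=C(N/C=N/c2ccc([N+](=O)[O-])cc2)Nc2[nH]nc(C)c2C1c1ccc(N(C)C)cc1`) remains unmeasured. Its change from compound 3 is a group of 11 heavy atoms (7 carbon, 2 nitrogen, 2 oxygen; one six-membered aromatic ring of carbon only) in place of a hydrogen atom, on an amine nitrogen in this case.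

Within the data shown here, two measured steps bear on this, both running in the reverse sense: a 9.0-fold lower number from compound 1 to compound 3 (0.95 log units; beyond the scatter) as a modest step and a 19-fold lower number from compound 2 to compound 3 (1.28 log units; beyond the scatter) as a large one. The group in compound 1 also holds an aromatic ring, so that smaller step is the closer guide. A rise is expected, and the estimated step is a 7.1-fold higher number from compound 3 to compound 4 (0.85 log units; beyond the scatter) overall. For compound 4 the estimate is 30000 nM within an expected range of 10000 nM to 90000 nM in this assay terms.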

Compound 4, half-maximal inhibitory concentration: 50900 nM
Beside the measured number, compound 4's estimate is 1.7-fold (0.23 log units) below it; low and high end bracket the measured number.
By their numbers in this assay, from the lowest: compound 3; then compounds 1, 4 and 2 (each within the scatter of the next, the first and the last beyond it).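

Placing a 4-nitrophenyl group on this amine nitrogen also costs activity in this assay (a 12-fold higher number from compound 3 to compound 4 (1.08 log units; beyond the scatter)), so the rise is not confined to the 5-sulfamoyl-1,3,4-thiadiazol-2-yl group or the ring-free group. Exchanging either of those groups for 4-nitrophenyl stays within the scatter (a 1.3-fold higher number from compound 1 to compound 4 (0.13 log units; within the scatter); a 1.6-fold lower number from compound 2 to compound 4 (0.20 log units; within the scatter)), and compound 3 remains the lowest of the four. No measured evidence accounts for these numbers.
Still open, as far as these compounds go, is whether a methyl or acetyl group on this nitrogen would preserve the number of compound 3.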